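Swapping a Methyl for a Formyl on the Pendant Ring

The compounds below may be only part of what the source reports. "The series", "measured", "known", "first", "only" and "open" are said of these compounds alone.

Measured so far:
compound 1 `O=Cc1ccc(-c2cn3ccnc3c(-c3ccc4ncn(C5CCCCC5)c4c3)n2)cc1` gives 1.5
compound 2 `Cc1cccc(-c2cn3ccnc3c(-c3ccc4ncn(Cc5ccccc5)c4c3)n2)c1` gives 2.16

Both numbers come from a physicochemical assay for lipophilicity, using the shake flask method, in phosphate buffer, measured as octanol-water partition, with a stated time of 85 min, at pH 7.4; a higher number here means a more lipophilic compound, a lower number a more polar compound. Of the two measured compounds, compound 2 stands higher: compound 1 lies a good way below it, and that gap is beyond the usual scatter of repeated measurements. The two compounds differ in more than one place, so no single change can be tied to that gap.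

Compound 3 `O=Cc1ccc(-c2cn3ccnc3c(-c3ccc4ncn(Cc5ccccc5)c4c3)n2)cc1` has not yet been measured. It differs from compound 2 in one place only: 4-formylphenyl in place of 3-methylphenyl on an aromatic carbon. The rest of the molecule is kept, including the benzyl group on the shared core. Compound 1 carries the same 4-formylphenyl group and gives 1.5 in this assay, which suggests that this group sits on the lower side of the measured range.

On that basis compound 3 is expected to fall below compound 2, with an estimated step of a number 0.76 log units lower from compound 2 to compound 3 (beyond the scatter), a drop beyond the scatter. The estimate for compound 3 in this assay is 1.4, with a range from 0.9 to 1.9.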

Compound 3, partition coefficient: 1.88
Compound 3: the middle estimate sits 0.48 log units below what was measured; measured number inside the range.
By their numbers in this assay, from the lowest: compound 1; then compounds 3 and 2 (each within the scatter of the next).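

In this assay, 4-formylphenyl in place of 3-methylphenyl on an aromatic carbon of the shared core gives a number 0.28 log units lower from compound 2 to compound 3 (within the scatter) and so does not separate these two compounds, even though the entering group brings a carbonyl and one hydrogen-bond acceptor that the leaving group lacks. Within the data shown here, with 4-formylphenyl held constant, benzyl in place of cyclohexyl on an aromatic nitrogen gives a number 0.38 log units higher from compound 1 to compound 3 (beyond the scatter) as a modest change, so of the two single changes now readable, only the one on the nitrogen lies beyond the scatter. No measurement is available here that explains the size of either step.

The swap on the aromatic carbon alters both the kind of group and where it sits on the pendant ring, and these two compounds cannot show what each alteration contributes alone; 4-methylphenyl or 3-formylphenyl would divide the change into those two parts. Also open, going by these compounds, is whether a more different group on that ring, such as a carboxylic acid or an amine, would move the number beyond the scatter of compound 2.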